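Swapping a Pyridine Arm for Thiophene on a Shared Core

A few compounds are considered here, and "the series" means these few. Any claim that something is new, unique, unknown or untested is made for them only; others in the source may bear on it.

Compound 3 `Oc1ccc(-c2cc(-c3ccc(Cl)cc3)nc(-c3ccccn3)c2)cc1` was tested in an ADME assay on HEK293 cells (Homo sapiens) for cytotoxicity, read by CCK-8 assay and cell counting, with a stated time of 2 days (on this read-out higher numbers stand for weaker inhibition and lower numbers for stronger inhibition), where compound 3 gives 27200 nM. This is the higher of the two numbers in hand: compound 1 `Oc1ccc(-c2cc(-c3cccs3)nc(-c3ccccc3Cl)c2)cc1` gives 5220 nM, a lower number beyond the usual scatter, while compound 2 `Oc1ccc(-c2cc(-c3ccncc3)nc(-c3ccc(Cl)cc3)c2)cc1` gives "not determined" (no result reported). Compound 4 `Oc1ccc(-c2cc(-c3ccc(Cl)cc3)nc(-c3cccs3)c2)cc1` has not yet been measured. It differs from compound 3 in one place: thiophen-2-yl in place of pyridin-2-yl on an aromatic carbon. Going by the values given here, no measured pair shows this change on its own. Compound 1 also carries a thiophen-2-yl group and gives 5220 nM, so a moderate step toward a lower number is expected. For compound 4 the expected result in this assay is 12000 nM, within a range of 4000 nM to 35000 nM. That estimate means a step of a 2.3-fold lower number from compound 3 to compound 4 (0.36 log units; beyond the scatter).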

Compound 4, half-maximal inhibitory concentration: 4520 nM
Compound 4: middle estimate off by 2.7-fold (0.42 log units), on the high side; low and high end bracket the measured number.
By their numbers in this assay, from the lowest: compounds 4 and 1 (each within the scatter of the next); then compound 3.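

In this assay the change from pyridin-2-yl to thiophen-2-yl on this carbon next to the ring nitrogen, read on its own, gives a 6.0-fold lower number from compound 3 to compound 4 (0.78 log units; beyond the scatter) and so counts as a real difference. With thiophen-2-yl in place, 4-chlorophenyl in place of 2-chlorophenyl gives a 1.2-fold lower number from compound 1 to compound 4 (0.06 log units; within the scatter) and so shows no separation between these two chlorophenyl groups. No measurement at hand explains why the swap of rings shifts the number.

Still open, on these data alone, is how a plain phenyl ring, a furan-2-yl group or an amine on this carbon would read.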